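This account rests on a few compounds, and the source may have more. Where it says the series, first, only, none or still open, it means among the compounds named here.

Measured so far in an assay on CHO cells for displacement of a labelled ligand from adenosine receptor A1 (Homo sapiens), read by scintillation counting, tested at 10 uM; a higher number here means more inhibition at the concentration tested (going by the name of the read-out), a lower number less inhibition:
compound 1 `Cc1c(Br)sc(N)c1C(=O)c1ccc(Cl)cc1`: 1%
compound 2 `CC(C)(C)Cc1c(-c2ccc(F)cc2)sc(N)c1C(=O)c1ccc(Cl)cc1`: 1%
compound 3 `CC(C)(C)Cc1c(-c2ccc(OC(F)(F)F)cc2)sc(N)c1C(=O)c1ccc(Cl)cc1`: 1%

Compound 2 stands level with compound 1 and compound 3 at the digits shown; all three sit within the scatter of one another, so the measured set gives no spread to work from.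

Compound 4 `Cc1cccc(-c2sc(N)c(C(=O)c3ccc(Cl)cc3)c2CC(C)(C)C)c1` differs from compound 2 in one place: 3-methylphenyl in place of 4-fluorophenyl on an aromatic carbon. Among the measured compounds shown here, the only step that bears on this site is no change at the digits printed from compound 2 to compound 3 (within the scatter), a swap of one aryl substituent for another on the same aromatic carbon, which left the read-out where it was. On that basis the expected step in this assay is a number 1 percentage points higher from compound 2 to compound 4 (within the scatter), none beyond the scatter, in either direction.

Compound 4 is therefore estimated at 2%, with a range from 0% to 15%.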

Compound 4, a percentage reported as inhibition, at one concentration (the size of the read-out at that concentration, not a potency): 1%
Compound 4: the middle estimate sits 1 percentage points above what was measured; the measured number falls inside the stated range.
By their numbers in this assay, from the lowest: compounds 1, 2, 3 and 4 (each within the scatter of the next).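

In this assay, 3-methylphenyl in place of 4-fluorophenyl gives no change at the digits printed from compound 2 to compound 4 (within the scatter). Unlike the earlier step, this change moves the substituent to a different place on the phenyl ring and swaps fluorine for a carbon group, yet the read-out still does not respond. No available evidence explains this lack of response. With every compound shown within the scatter of the others, no group at this position is yet linked to any inhibition. From the compounds shown here alone, it remains open whether an aminophenyl or carboxyphenyl group here, or a longer chain in place of neopentyl, would change the read-out.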